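Trifluoromethyl for methyl on the weaker core of compound 3

The source may hold more compounds than are shown below. What is called first, only, known or untested is meant among the compounds shown, and "the series" means these compounds.

Compound 1 `CNc1nc(-c2cc(OC)c(OC)c(OC)c2)c(-c2ccc(C)cc2)s1` gives 125 nM in a functional assay on A549 cells (Homo sapiens) for antiproliferative activity, read by MTT assay, with a stated time of 72 h; a lower number here means a stronger inhibitor, a higher number a weaker inhibitor. Compound 2 `CNc1nc(-c2cc(OC)c(OC)c(OC)c2)c(-c2ccc(C(F)(F)F)cc2)s1` differs from compound 1 in one place, (trifluoromethyl in place of methyl on an aromatic carbon), and in this assay compound 2 gives 4570 nM; the step is a 37-fold higher number from compound 1 to compound 2 (1.56 log units; beyond the scatter). Compound 3 `COc1cc(-c2nc(C)sc2-c2ccc(C)cc2)cc(OC)c1OC` has a different core from compound 1; the difference between the two cores is methyl in place of methylamino on an aromatic carbon. In this assay compound 3 gives 1950 nM, a step of a 16-fold higher number from compound 1 to compound 3 (1.19 log units; beyond the scatter). Compound 3 stands second highest of the three measured numbers, with compound 2 higher and compound 1 far lower.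

Compound 4 `COc1cc(-c2nc(C)sc2-c2ccc(C(F)(F)F)cc2)cc(OC)c1OC` has not been measured in this assay. It differs from compound 3 by trifluoromethyl in place of methyl on an aromatic carbon, and the place is described in the same words as for the change from compound 1 to compound 2, so this is the same change made on the other core; it occurs in two pairs among the compounds shown, one of them measured.

The one measured occurrence gave a 37-fold higher number from compound 1 to compound 2 (1.56 log units; beyond the scatter). For compound 4 a step of similar direction is expected, estimated at a 21-fold higher number from compound 3 to compound 4 (1.31 log units; beyond the scatter), resting only on that single step and on compound 3 already standing at 1950 nM. Whether a step of this size carries over from the core of compound 1 to the core of compound 3 cannot be checked from the data, so the range is kept wide. Compound 4 is expected to give about 40000 nM in this assay, between 10000 nM and 150000 nM.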

Compound 4, half-maximal inhibitory concentration: 4290 nM
Compound 4: middle estimate off by 9.3-fold (0.97 log units), on the high side; measured number outside the range, below it.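

In this assay, trifluoromethyl for methyl keeps its direction on the second core but not its size, with a 2.2-fold higher number from compound 3 to compound 4 (0.34 log units; beyond the scatter) set against a 37-fold higher number from compound 1 to compound 2 (1.56 log units; beyond the scatter) on the core of compound 1: the same change on two cores in this assay, a 37-fold higher number (1.56 log units; beyond the scatter) from compound 1 to compound 2 and a 2.2-fold higher number (0.34 log units; beyond the scatter) from compound 3 to compound 4, 17-fold (1.22 log units) apart, beyond the scatter of two such steps.

The same four compounds read the other way show that methyl for methylamino depends on the group at the other site, with a 16-fold higher number from compound 1 to compound 3 (1.19 log units; beyond the scatter) when the aromatic ring carries methyl but a 1.1-fold lower number from compound 2 to compound 4 (0.03 log units; within the scatter), within the scatter, when it carries trifluoromethyl: the same change on two cores in this assay, a 16-fold higher number (1.19 log units; beyond the scatter) from compound 1 to compound 3 and a 1.1-fold lower number (0.03 log units; within the scatter) from compound 2 to compound 4, 17-fold (1.22 log units) apart, beyond the scatter of two such steps.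

So the two changes do not add up in this set, and a step measured on one core is a poor guide to its size on the other, but this rests on a single square of compounds in one assay, in which compound 1 alone stands apart from the other three, and it gives no reason for the gap and no rule for the series beyond these four.

The compounds shown leave open whether other groups in place of methyl on the aromatic ring, such as chlorine or ethyl, behave like methyl or like trifluoromethyl on either core. They also leave open whether a free amine or a longer chain such as ethylamino in place of methylamino would keep the standing of compound 1 .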